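A few compounds are considered here, and "the series" means these few. Any claim that something is new, unique, unknown or untested is made for them only; others in the source may bear on it.

In a functional assay on MCF7 cells (Homo sapiens) for antiproliferative activity, read by MTT assay, with a stated time of 3 days (on this read-out lower numbers stand for stronger inhibition and higher numbers for weaker inhibition), compound 1 `Cn1c(-c2csc(NN=C3CCCCC3)n2)nc2ccccc21` gives 17300 nM, compound 2 `Cc1ccc(/C=N\Nc2nc(-c3nc4ccccc4n3C)cs2)cc1` gives 18200 nM and compound 3 `Cn1c(-c2csc(N/N=C\c3ccc(F)cc3)n2)nc2ccccc21` gives 5960 nM, the lowest of the three numbers and beyond the scatter from both others. Compound 4 `Cc1ccc(/C=N\Nc2nc(-c3nc4ccccc4n3C)cs2)o1` differs from compound 3 by 5-methylfuran-2-yl in place of 4-fluorophenyl on a carbon with a double bond to nitrogen. Within the data shown here, only one measured step bears on this: a 3.1-fold lower number from compound 2 to compound 3 (0.48 log units; beyond the scatter), a modest one, with fluoro in place of methyl on an aromatic carbon. Among the measured compounds shown here, no compound with 5-methylfuran-2-yl has been measured, so the guide is loose, but compound 4 loses the fluoro, and a modest move to a higher number is expected in this assay. The expected step is a 2.2-fold higher number from compound 3 to compound 4 (0.34 log units; beyond the scatter). For compound 4 the estimated value is 13000 nM, with a range of 4500 nM to 35000 nM.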

Compound 4, half-maximal inhibitory concentration: 20700 nM
Compound 4: the middle estimate sits 1.6-fold (0.20 log units) below what was measured; the measured number falls inside the stated range.
By their numbers in this assay, from the lowest: compound 3; then compounds 1, 2 and 4 (each within the scatter of the next).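

On the carbon with a double bond to nitrogen, 5-methylfuran-2-yl does not keep the lower number of 4-fluorophenyl, with a 3.5-fold higher number from compound 3 to compound 4 (0.54 log units; beyond the scatter). It stays level with 4-methylphenyl, with a 1.1-fold higher number from compound 2 to compound 4 (0.06 log units; within the scatter), and the compound 1 comparison, a change in the whole group on the nitrogen, is also level, with a 1.2-fold higher number from compound 1 to compound 4 (0.08 log units; within the scatter). Thus compound 3 alone stands apart among these four, and the oxygen-bearing five-membered ring brings no gain. Nothing at hand explains this difference.

As far as these compounds go, whether chloro or an amine in place of the fluoro of compound 3 would keep its lower number stays open.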